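A few compounds are considered here, and "the series" means these few. Any claim that something is new, unique, unknown or untested is made for them only; others in the source may bear on it.

Compound 1 `CCCCCCC#Cc1ccc(S(=O)(=O)Nc2cccc(-c3csc(NC(C)=O)n3)c2)cc1` gives 5.8% in a functional assay on A-375 cells (Homo sapiens) for antiproliferative activity, read by trypan blue exclusion, with a stated time of 48 h, tested at 10 uM; a higher number here means a weaker effect of the compound at the concentration tested, a lower number a stronger effect.
Compound 2 `C#Cc1ccc(S(=O)(=O)Nc2cccc(-c3csc(NC(C)=O)n3)c2)cc1` gives 1.2% in this assay.
Compound 3 `CCCCCCCCC#Cc1ccc(S(=O)(=O)Nc2cccc(-c3csc(NC(C)=O)n3)c2)cc1` is reported in this assay only as a limit, < 1%, not as a number; that is the limit of < 1% in this assay, at which 1 of the 3 values shown sits.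

Of the two actual numbers, compound 1 is the higher, with compound 2 nearest at a number 4.6 percentage points lower from compound 1 to compound 2 (within the scatter), a gap within the scatter. The step of a number at least 4.8 percentage points lower from compound 1 to compound 3 (that floor lies within the scatter) and the step of a number at least 0.2 percentage points lower from compound 2 to compound 3 (that floor lies within the scatter) end at a limit and so only set a floor. All three compounds share the same core and the same acetyl on the ring nitrogen; they differ only in the chain on the triple-bonded carbon.

Compound 4 `CCCCCCC#Cc1ccc(S(=O)(=O)Nc2cccc(-c3csc(Nc4ccccc4)n3)c2)cc1` keeps the chain of compound 1 and alters the other end: phenyl in place of acetyl on a nitrogen on an aromatic ring. Going by the values given here, none of the measured steps touches this nitrogen, so no measured step bears on the change directly. What the measured steps do show is that the read-out stays within the scatter while the chain is varied widely. The expected step is therefore a number 0.8 percentage points lower from compound 1 to compound 4 (within the scatter), none beyond the scatter. Compound 4 is estimated at 5% in this assay, with a range from 1% to 20%.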

Compound 4, a percentage reported as activity, at one concentration (the size of the read-out at that concentration, not a potency): 5.8%
Compound 4: the middle estimate sits 0.8 percentage points below what was measured, and the stated range covers the measured number.
By their numbers in this assay, from the lowest: compounds 2, 1 and 4 (each within the scatter of the next). At a limit, below all of these: compound 3.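

In this assay, the change from acetamido to anilino gives no change at the digits printed from compound 1 to compound 4 (within the scatter). Going by these compounds alone, the earlier compounds differed only in the chain on the triple-bonded carbon, so this is the first look at the nitrogen at the other end of the molecule, and it shows that acetyl, with 3 heavy atoms and a double bond outside aromatic rings, can give way to phenyl, with 6 heavy atoms and a six-membered aromatic ring, without a difference beyond the usual scatter at this single concentration. Nothing shown here explains why the two groups read alike.

The compounds shown leave open whether this nitrogen would accept very different groups, such as a free amine in place of the acetamido or a carboxylic acid on the phenyl. They also leave open how the anilino end behaves when it is paired with the other chains, such as the octyl of compound 3 or the hydrogen of compound 2, or with a longer chain.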